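A new ring group on compound 3

The source may hold more compounds than are shown below. What is called first, only, known or untested is meant among the compounds shown, and "the series" means these compounds.

Values so far in an ADME assay (liver) for metabolic stability, with Liver microsome (Homo sapiens) as the target, using microsomes (a higher number here means that the compound lasts longer, a lower number that the compound disappears faster), as half-life:
Compound 1 `CCc1nc2ccc(Cl)cn2c1C(=O)NCc1ccc(-c2ccccc2Cl)cc1` gives 0.648 h
Compound 2 `CCc1nc2ccc(Cl)cn2c1C(=O)NCc1ccc(-c2ccc(C)cc2)cc1` gives 0.508 h
Compound 3 `CCc1nc2cc(Cl)ccn2c1C(=O)NCc1ccc(-c2ccncc2)cc1` gives 0.482 h

In this assay the value of compound 3 lies within the usual scatter of both compound 1 and compound 2, so these three numbers cannot be ranked. The next structure is compound 4 `CCc1nc2cc(Cl)ccn2c1C(=O)NCc1ccc(-n2cc3c(c2)CCCC3)cc1` which carries a group of 9 heavy atoms (8 carbon, 1 nitrogen; one five-membered aromatic ring with 1 hetero atom, one six-membered non-aromatic ring of carbon only) in place of a group of 6 heavy atoms (5 carbon, 1 nitrogen; one six-membered aromatic ring with 1 hetero atom), on an aromatic carbon as its change from compound 3. Pyridin-4-yl leaves, and the entering group brings a five-membered aromatic ring and a six-membered non-aromatic ring of carbon only. The exchange takes place on an aromatic carbon of a six-membered aromatic ring of carbon only, para to a large group.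

For the measured compounds named here, one measured step bears on this. It is a 1.3-fold lower number from compound 1 to compound 2 (0.11 log units; within the scatter) and it exchanges one ring group for another while staying within the scatter. Going by the values given here, no measured compound carries the entering group, so that step is only a weak guide, and the range around any estimate has to stay wide. The expected step is a 1.1-fold lower number from compound 3 to compound 4 (0.06 log units; within the scatter) which stays within the scatter, with a slight lean towards a lower number. For compound 4 the estimated half-life is 0.42 h with an expected range from 0.2 h to 0.75 h in this measurement.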

Compound 4, half-life: 0.455 h
Compound 4: the middle estimate sits 1.1-fold (0.03 log units) below what was measured, and the stated range covers the measured number.
By their numbers in this assay, from the lowest: compounds 4, 3, 2 and 1 (each within the scatter of the next).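

In this assay, the exchange of pyridin-4-yl for a group with a five-membered aromatic ring and a six-membered non-aromatic ring of carbon only gives a 1.1-fold lower number from compound 3 to compound 4 (0.03 log units; within the scatter) and so stays within the scatter. The earlier step had exchanged only one six-membered aromatic ring group for another, so this is the first sign among the compounds shown that a group of two rings, with more heavy atoms than the one it replaces, can be placed on this aromatic carbon, para to a large group, without the half-life leaving the scatter. Nothing in the material shown explains why the half-life holds at this place.

The compounds shown leave open whether a group of another kind on this carbon, such as a morpholine ring, a primary amine or a carboxylic acid, would take the half-life beyond the scatter. They also leave open whether a change elsewhere on the shared core would separate numbers that the ring groups at this place have so far left within the scatter of one another.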